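This account rests on a few compounds, and the source may have more. Where it says the series, first, only, none or still open, it means among the compounds named here.

In an ADME assay on microsomes from liver (Homo sapiens) for metabolic stability, with a stated time of 10 min, tested at 0.5 uM (on this read-out lower numbers stand for a less stable compound and higher numbers for a more stable compound), compound 1 (`Cc1noc(C)c1[C@@H]1C[C@@](C)(c2ccc(F)cc2F)N=C(N)S1`) gives 24%. Compound 3 (`Cc1onc(-c2cccnc2)c1[C@@H]1C[C@@](C)(c2ccc(F)cc2F)N=C(N)S1`) gives 17%, within the scatter of compound 1, while compound 2 (`Cc1noc(C)c1[C@@H]1C[C@@](C)(c2ccc(F)cc2)N=C(N)S1`) stands well apart at 73%. Compound 4 (`Cc1noc(C(F)F)c1[C@@H]1C[C@@](C)(c2ccc(F)cc2F)N=C(N)S1`) differs from compound 1 by one change: difluoromethyl in place of methyl on an aromatic carbon. Within the data shown here, the closest precedent also replaces a methyl: a number 7 percentage points lower from compound 1 to compound 3 (within the scatter), so no step beyond the scatter is expected. The other measured step, a number 49 percentage points higher from compound 1 to compound 2 (beyond the scatter), is large but concerns a fluoro rather than a methyl, so it bears only loosely and leaves some room upward. The estimated step is a number 6 percentage points higher from compound 1 to compound 4 (within the scatter). The expected value for compound 4 is 30%, with an estimated range from 14% to 55%.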

Compound 4, percent of the compound remaining: 35%
Compound 4: middle estimate off by 5 percentage points, on the low side; the range from low to high includes it.
By their numbers in this assay, from the lowest: compounds 3 and 1 (each within the scatter of the next); then compound 4; then compound 2.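

Among these compounds, the earlier compounds left the methyl next to the ring oxygen unchanged, so this is the first reading at that position. In this assay, difluoromethyl in place of that methyl gives a number 11 percentage points higher from compound 1 to compound 4 (beyond the scatter), showing that the read-out responds to a change at this carbon and that the larger group costs no stability. Nothing available here explains the shift.

From the compounds shown here alone, it remains open whether trifluoromethyl, ethyl or a methoxymethyl group at this carbon would move the value further. Going by these compounds, it is also open whether difluoromethyl would give a similar step on the core of compound 2.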